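Hexyl to iodo on the aryl urea: expected whole-organism effect

The source may report more compounds than this note shows. Statements on the series, on what has been measured and on what is new or still open speak of the compounds shown alone.

Within the data shown here, in an ADME assay on the whole organism with Oryza sativa as the target, tested at 1 uM (a higher number here means a weaker effect of the compound at the concentration tested, a lower number a stronger effect), compound 1 `CCCCCCc1ccc(NC(=O)N[C@H](C)c2ccccc2)cc1` gives 101%, the highest of the two numbers so far, with compound 2 `CCCCCCc1ccc(NC(=O)N[C@@H](C)c2ccccc2)cc1` nearest at 100%. Among the measured compounds shown here, the only measured step, a number 1 percentage points lower from compound 1 to compound 2 (within the scatter), is within the scatter; the two compounds differ only in configuration as drawn (the fact that compounds 1 and 2 differ only in the configuration as drawn), so nothing separates them on this read-out.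

Compound 3 `C[C@@H](NC(=O)Nc1ccc(I)cc1)c1ccccc1` is to be measured in this assay. Against compound 1 the change is iodo in place of hexyl on an aromatic carbon. For the measured compounds named here, no measured step touches the hexyl chain or the iodo group, so no step bears on this change, and the values of compound 1 and compound 2 only show that the shared core with hexyl gives no effect at the concentration tested. Without evidence on the change, the step of a number 6 percentage points lower from compound 1 to compound 3 (within the scatter) is expected to be small, if any, and the range must stay wide. Compound 3 is therefore estimated at 95%, expected between 70% and 110%.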

Compound 3, a percentage reported as activity, at one concentration (the size of the read-out at that concentration, not a potency): 91%
Compound 3: middle estimate off by 4 percentage points, on the high side, and the stated range covers the measured number.
By their numbers in this assay, from the lowest: compounds 3, 2 and 1 (each within the scatter of the next).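

In this assay, iodo in place of hexyl on an aromatic carbon, para to a large group, gives a number 10 percentage points lower from compound 1 to compound 3 (within the scatter). Among these compounds, at this position the read-out therefore does not tell the hexyl chain, with 6 heavy atoms, from iodo, with 1 heavy atom, so a first change at this place, unlike the change of configuration between the two earlier compounds, also leaves the numbers within the scatter. Nothing available bears on why these two groups are not told apart.

Open, from the compounds shown here alone, is whether an amine, a carboxylic acid or a longer chain at this position would stand apart from hexyl and iodo. Also open, going by these compounds, is whether the configuration at the saturated chain carbon would count with iodo on the ring.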